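The source may report more compounds than this note shows. Statements on the series, on what has been measured and on what is new or still open speak of the compounds shown alone.

Two compounds of a shared core have been taken through an ADME assay on the whole organism (strain Sprague-Dawley) for pharmacokinetics, with Rattus norvegicus as the target, read by LC-MS, at a dose of 25 mg/kg by the oral route; a lower number here means less compound in the circulation, a higher number more compound in the circulation at the dose given. Compound 1, `C=CC(=O)Nc1cccc(-n2c(=O)cc(C)c3cnc(Nc4ccccc4Nc4nc5c(s4)CN(C)CC5)nc32)c1`, gives 26.6 ng.h/mL in this assay. Compound 2, `C=CC(=O)Nc1cc(-n2c(=O)cc(C)c3cnc(Nc4ccc(N5CCN(C)C(C)C5)cc4OC)nc32)cc(C(F)(F)F)c1`, gives 111 ng.h/mL in this assay, the higher of the two numbers, and the gap between compound 1 and compound 2 lies beyond the scatter of repeated measurements. The two compounds differ in more than one place, so the two values alone cannot be tied to any single change.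

Compound 3, `C=CC(=O)Nc1cccc(-n2c(=O)cc(C)c3cnc(Nc4ccc(N5CCN(C)C(C)C5)cc4OC)nc32)c1`, has not yet been measured. It is compound 2 with one alteration: hydrogen in place of trifluoromethyl on an aromatic carbon. Compound 1 also carries hydrogen at that position, but its other differences from compound 2 leave the size of this step open. The step from compound 2 to compound 3 in this assay is expected to be small to moderate and downward, as a 1.9-fold lower number from compound 2 to compound 3 (0.27 log units; within the scatter). Compound 3 is thus expected to give about 60 ng.h/mL in this assay, within a range from 20 ng.h/mL to 180 ng.h/mL.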

Compound 3, area under the concentration-time curve: 526 ng.h/mL
Beside the measured number, compound 3's estimate is 8.8-fold (0.94 log units) below it, and the stated range ends below it.
By their numbers in this assay, from the lowest: compound 1; then compound 2; then compound 3.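

In this assay, within the data shown here, hydrogen in place of trifluoromethyl on this aromatic carbon, meta to a (vinylcarbonyl)amino group, gives a 4.7-fold higher number from compound 2 to compound 3 (0.68 log units; beyond the scatter) and provides the first reading of this position on its own. Within this pair, the compound carrying trifluoromethyl therefore has the lower number and the compound carrying hydrogen the higher one, which compound 1 and compound 2 could not show, as they differ in more than one place. No measurement shown here explains the size of this step.

On these data alone, only these two substituents can be compared at this carbon, so it remains open whether a fluorine atom, a chlorine atom, a methyl group or a methoxy group there would fall nearer to hydrogen or to trifluoromethyl. As far as these compounds go, it also remains open whether the same change would give a step of similar size on a compound bearing the other groups of compound 1.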